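The source may report more compounds than this note shows. Statements on the series, on what has been measured and on what is new or still open speak of the compounds shown alone.

Working notes on the step from compound 1 (`Nc1ccn([C@@H]2C=C(F)[C@H](CO)O2)c(=O)n1`) to compound 3 (`O=c1nc(O)ccn1[C@@H]1C=C(F)[C@H](CO)O1`). In a functional assay on Vero cells (Chlorocebus sabaeus) for cytotoxicity (a lower number here means a stronger inhibitor, a higher number a weaker inhibitor), compound 1 gives > 100000 nM, which is a limit and not a number. Among the compounds with values here, the one measured neighbour is compound 2 (`Nc1nc(=O)n([C@@H]2C=C(F)[C@H](CO)O2)cc1F`). In this assay compound 2 gives > 100000 nM, which is likewise a limit. Within the data shown here, the series so far therefore stands at the limit of > 100000 nM in this assay, at which 2 of the 2 values shown sit.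

The change to compound 3 is hydroxy in place of amino on an aromatic carbon, opposite the ring nitrogen. Among the measured compounds shown here, the only measured step is a step that the two limits leave unreadable from compound 1 to compound 2, for fluoro in place of hydrogen on an aromatic carbon. That is a different change, and it offers no size to carry over. Neither measured compound gives a number, so no step beyond the scatter is expected in this assay, and no direction can be assigned. The expected outcome is a number no higher from compound 1 to compound 3 (the limit leaves the size open), and a further limit is the likeliest report. For compound 3 the estimated value is 100000 nM, with an expected range of 40000 nM to 250000 nM.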

Compound 3, half-maximal inhibitory concentration: > 100000 nM
Compound 3: no number, only a limit (the forecaster's own chance of this, stated with the estimate: 85%); the middle value lies on the limit itself.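

In this assay compound 3 gives > 100000 nM, a limit and not a number. Within the data shown here, compound 1 also stands at a limit, so no step from compound 1 to compound 3 can be read. The compounds shown leave open what size of effect, and in which direction, any of these changes has, as the series offers only one reading: the limit of > 100000 nM in this assay, at which 3 of the 3 values shown sit.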